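This account rests on a few compounds, and the source may have more. Where it says the series, first, only, none or still open, it means among the compounds named here.

In a functional assay on Jurkat cells (Homo sapiens) (a higher number here means a weaker inhibitor, a lower number a stronger inhibitor), compound 1 (`CC(C)[C@H](NC(=O)COc1cccc2ccccc12)C(=O)N[C@@H](CC(=O)O)C(=O)COc1ccc2ccccc2c1`) gives > 100000 nM as a limit of the assay. Compound 2 (`CC(C)[C@H](NC(=O)COc1cccc2ccccc12)C(=O)N[C@@H](CC(=O)O)C(=O)COc1cccc(F)c1`) gives > 100000 nM as a limit too. Compound 3 (`CC(C)[C@H](NC(=O)COc1cccc2ccccc12)C(=O)N[C@@H](CC(=O)O)C(=O)COc1ccc(F)c(F)c1`) gives > 100000 nM as a limit as well, so it has no number of its own and stands with the other two (the limit of > 100000 nM in this assay, at which 3 of the 3 values shown sit).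

Compound 4 (`CC(C)[C@H](NC(=O)COc1cccc2ccccc12)C(=O)N[C@@H](CC(=O)O)C(=O)COc1c(F)cc(F)cc1F`) carries 2,4,6-trifluorophenyl in place of 3,4-difluorophenyl on an oxygen on a saturated carbon. The measured changes at this same place are a step that the two limits leave unreadable from compound 1 to compound 2 and a step that the two limits leave unreadable from compound 1 to compound 3 and also a step that the two limits leave unreadable from compound 2 to compound 3 in the series. None of these has a size that can be carried over to the new group. With the limit of compound 3 at > 100000 nM any readable number would mean a stronger inhibitor, so only that direction is open.

The expected change is an at least 3.3-fold lower number from compound 3 to compound 4 (0.52 log units; beyond the scatter) and its size is poorly bounded. The estimate for compound 4 is 30000 nM with an expected range from 3000 nM to 100000 nM and a real chance of only a limit.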

Compound 4, half-maximal inhibitory concentration: 6840 nM
Beside the measured number, compound 4's estimate is 4.4-fold (0.64 log units) above it; the range from low to high includes it.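

The change to 2,4,6-trifluorophenyl gives an at least 14-fold lower number from compound 3 to compound 4 (1.16 log units; beyond the scatter) in this assay and so shows that, with the rest of the core of compound 1 unchanged, the group on this oxygen can bring the series to a readable number. Against the other two groups the same change gives an at least 14-fold lower number from compound 2 to compound 4 (1.16 log units; beyond the scatter) and also an at least 14-fold lower number from compound 1 to compound 4 (1.16 log units; beyond the scatter) and, like the first step, each of these is bounded on one side only, with the full size unknown. The steps among compound 1, compound 2 and compound 3 cannot be read, and only compound 4 has a number of its own: the limit of > 100000 nM in this assay, at which 3 of the 4 values shown sit.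

From the compounds shown here alone, whether the lower number follows the count of fluorines or their placement stays open, as 2,4,6-trifluorophenyl differs from 3,4-difluorophenyl in both. Going by these compounds, how 2,6-difluorophenyl, pentafluorophenyl or 2,4,6-trichlorophenyl would read at this place also stays open.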